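Anilide para-substituent swap: methoxy to fluoro

The source may hold more compounds than are shown below. What is called first, only, known or untested is meant among the compounds shown, and "the series" means these compounds.

Two compounds of the shared core have numbers in a functional assay on CHO cells for agonist activity at Melanocyte-stimulating hormone receptor (Homo sapiens), read by a luciferase reporter, with a stated time of 4 h; on this read-out lower numbers stand for an effect already at smaller amounts and higher numbers for an effect only at larger amounts of compound. Compound 1 `COc1ccc(N(C(=O)CN2C=CN(c3ccccc3)C(=O)C(Cc3n[nH]c4ccccc34)(OC)C2=O)C(C)C)cc1` gives 1380 nM in this assay. Compound 2 `CC(C)N(C(=O)CN1C=CN(C)C(=O)C(Cc2n[nH]c3cc(F)ccc23)C1=O)c1ccc(F)cc1` gives 3720 nM in this assay. Compound 1 therefore stands at the lowest of the two numbers, with compound 2 the nearest at a higher number that lies beyond the scatter. Among the compounds with values here, no pair of measured compounds differs in a single place, so no single-point step in this assay is known.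

The next compound, compound 3 `COC1(Cc2n[nH]c3ccccc23)C(=O)N(CC(=O)N(c2ccc(F)cc2)C(C)C)C=CN(c2ccccc2)C1=O`, is reached from compound 1 by one change: fluoro in place of methoxy on an aromatic carbon. The rest of compound 1, including the methoxy at the quaternary position of the core, is kept.

Within the data shown here, with no comparable single-point step available, the expectation for the change from compound 1 to compound 3 rests on the small size of the difference alone. A step no larger than the scatter is expected, a 1.3-fold higher number from compound 1 to compound 3 (0.12 log units; within the scatter), with a slight lean towards a higher number. Compound 3 is thus estimated at 1800 nM in this assay, within a range from 700 nM to 4500 nM.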

Compound 3, half-maximal effective concentration: 2950 nM
Estimate against measurement, compound 3: 1.6-fold (0.21 log units) below; measured number inside the range.
By their numbers in this assay, from the lowest: compound 1; then compounds 3 and 2 (each within the scatter of the next).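

In this assay this position now has its first single-point step: a 2.1-fold higher number from compound 1 to compound 3 (0.33 log units; beyond the scatter) when 4-methoxyphenyl gives way to 4-fluorophenyl, and all other parts of the molecule are kept. The step is modest, but it shows that the number responds to the group on the aromatic carbon para to a large group, with methoxy the better of the two groups compared and the exchange still leaving a measurable effect, as compound 3 gives 2950 nM in this read-out. Nothing in the available data explains the direction or size of this step.

One exchange in one setting cannot show whether the number follows the size of the group, its atoms or something else, and a hydroxyl, a nitrile, a dimethylamino group or a longer chain such as ethoxy at this position would test how far the trend extends. On these data alone, it also remains open whether the same exchange gives a step of similar size on a core that lacks the methoxy at the quaternary position or carries a group other than phenyl on the ring nitrogen.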